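The source may hold more compounds than are shown below. What is called first, only, known or untested is meant among the compounds shown, and "the series" means these compounds.

Compound 1 `CCC(CC)n1c(-c2ccc(OCc3c(-c4c(Cl)cccc4Cl)noc3C(C)C)cc2)nc2ccc(C(=O)O)cc21` and compound 2 `CCCC(CCC)n1c(-c2ccc(OCc3c(-c4c(Cl)cccc4Cl)noc3C(C)C)cc2)nc2ccc(C(=O)O)cc21` share one core and differ only at the aromatic nitrogen. In an assay on HEK-293T cells for antagonist activity at vitamin D3 receptor (Homo sapiens), read by a luciferase reporter, with a stated time of 24 h (a higher number here means a weaker inhibitor, a lower number a stronger inhibitor), compound 1 gives 5690 nM. Compound 2 reaches only the limit of this assay, reporting > 10000 nM, so no number is known for it. The step of an at least 1.7-fold higher number from compound 1 to compound 2 (0.24 log units; that floor lies within the scatter) therefore rests on a limit, and its floor lies within the scatter; the evidence is simply (the limit of > 10000 nM in this assay, at which 1 of the 2 values shown sits). Compound 3 `CC(C)c1onc(-c2c(Cl)cccc2Cl)c1COc1ccc(-c2nc3ccc(C(=O)O)cc3n2-c2ccc(F)cc2)cc1` carries 4-fluorophenyl in place of 1-propylbutyl on an aromatic nitrogen. Within the data shown here, no measured step exchanges a chain for an aromatic ring at this nitrogen, so the single step from compound 1 to compound 2 is the only guide, and it sets no direction. Compound 3 is thus expected to stay near the weak end of this assay, with the step of an at least 1.2-fold lower number from compound 2 to compound 3 (0.09 log units; that floor lies within the scatter). The estimate for compound 3 is 8000 nM, between 2000 nM and 30000 nM, and a limit is again quite possible.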

Compound 3, half-maximal inhibitory concentration: 2410 nM
Estimate against measurement, compound 3: 3.3-fold (0.52 log units) above; measured number inside the range.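

In this assay, 4-fluorophenyl on the aromatic nitrogen gives a stronger inhibitor than either branched chain, with an at least 4.1-fold lower number from compound 2 to compound 3 (0.61 log units; beyond the scatter) against 1-propylbutyl and a 2.4-fold lower number from compound 1 to compound 3 (0.37 log units; beyond the scatter) against pentan-3-yl. Compound 2 stands only at a limit of the assay, so the step from it is a floor and not a size: the limit of > 10000 nM in this assay, at which 1 of the 3 values shown sits. Unlike the exchange of one chain for the other, whose floor lay within the scatter, the exchange of a chain for this aromatic ring sets a direction at this position, though the measured size of the change is modest.

Going by these compounds, it remains open whether the ring itself or its fluorine carries this difference, which an unsubstituted phenyl would separate. Also open, on these data alone, is how a cyclohexyl ring or a shorter chain such as isopropyl would read at this nitrogen.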